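Pyridin-2-yl in Place of an Aminophenyl Group

The source may report more compounds than this note shows. Statements on the series, on what has been measured and on what is new or still open speak of the compounds shown alone.

Compound 3, `COc1ccc([C@H]2CC(=O)N(c3cc(N)cc(F)c3)C2)cc1OC1CCCC1`, is tested in a functional assay on HEK293 cells (Homo sapiens) for cytotoxicity; a higher number here means that more compound is tolerated, a lower number that less compound is tolerated. In that assay compound 3 reaches only a limit, > 10000 nM. Compound 1, `COc1ccc([C@H]2CC(=O)N(Cc3cccc(N)c3)C2)cc1OC1CCCC1`, likewise gives a limit, > 10000 nM. Compound 2, `COc1ccc([C@H]2CC(=O)N(c3ccc(C)c(N)c3)C2)cc1OC1CCCC1`, also gives a limit, > 10000 nM. Because of the limit of > 10000 nM in this assay, at which 3 of the 3 values shown sit, the steps a step that the two limits leave unreadable from compound 1 to compound 2, a step that the two limits leave unreadable from compound 1 to compound 3 and a step that the two limits leave unreadable from compound 2 to compound 3 have no readable size. Compound 4, `COc1ccc([C@H]2CC(=O)N(c3ccccn3)C2)cc1OC1CCCC1`, differs from compound 3 by pyridin-2-yl in place of 3-amino-5-fluorophenyl on an amide-type nitrogen in a ring. Among the compounds with values here, none of the measured steps offers a readable size, so nothing points to a change beyond the scatter, and the shared limits are the only guide. Compound 4 is therefore expected to give 15000 nM, within a range from 7000 nM to 40000 nM. The step implied by this estimate, a step that the limit leaves unreadable from compound 3 to compound 4, is expected to stay within the scatter.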

Compound 4, half-maximal cytotoxic concentration: > 10000 nM
Compound 4: no number, only a limit; the forecaster's own chance of this, stated with the estimate: 85%; the middle value is on the limit's open side.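

No step from compound 1, compound 2 or compound 3 to compound 4 can be read: the limit of > 10000 nM in this assay, at which 4 of the 4 values shown sit.

The compounds shown leave open whether any group on the amide-type nitrogen changes how much compound is tolerated in this assay.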